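The source may report more compounds than this note shows. Statements on the series, on what has been measured and on what is new or still open speak of the compounds shown alone.

Of the compounds shown here, three built on one shared core have been tested in a functional assay on NCI-H1975 cells (Homo sapiens) for inhibition, read by CellTiter-Glo, with a stated time of 72 h; a higher number here means a weaker inhibitor of growth, a lower number a stronger inhibitor of growth. Compound 1 `C=CC(=O)Nc1cc(Nc2ncc(Cl)c(Nc3ccccc3S(=O)(=O)C(C)C)n2)c(OC)cc1N1CCN(S(C)(=O)=O)CC1` gives 40 nM, and compound 2 `C=CC(=O)Nc1cc(Nc2ncc(Cl)c(Nc3ccccc3S(=O)(=O)C(C)C)n2)c(OC)cc1N1CCN(C(C)C)CC1` gives 25 nM; the step of a 1.6-fold lower number from compound 1 to compound 2 (0.20 log units; within the scatter) stays within the scatter. Compound 3 `C=CC(=O)Nc1cc(Nc2ncc(Cl)c(Nc3ccccc3C#N)n2)c(OC)cc1N1CCN(CC)CC1` gives 440 nM, the highest of the three numbers and clearly apart from both compound 1 and compound 2. Compound 4 `C=CC(=O)Nc1cc(Nc2ncc(Cl)c(Nc3ccccc3C#N)n2)c(OC)cc1N1CCN(C(C)C)CC1` differs from compound 3 by methyl in place of hydrogen on a saturated chain carbon bound to an amine nitrogen in a ring and a saturated chain carbon. Within the data shown here, no measured pair shows exactly this change; the only measured change on that ring nitrogen, a 1.6-fold lower number from compound 1 to compound 2 (0.20 log units; within the scatter), stayed within the scatter, so compound 4 is expected to remain close to compound 3. The expected step is a 1.1-fold lower number from compound 3 to compound 4 (0.04 log units; within the scatter) in this assay. Compound 4 is therefore estimated at 400 nM, with a likely range from 200 nM to 900 nM.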

Compound 4, concentration for 50% growth inhibition: 430 nM
Beside the measured number, compound 4's estimate is 1.1-fold (0.03 log units) below it; low and high end bracket the measured number.
By their numbers in this assay, from the lowest: compounds 2 and 1 (each within the scatter of the next); then compounds 4 and 3 (each within the scatter of the next).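

Ethyl to isopropyl on the ring nitrogen, a 1.0-fold lower number from compound 3 to compound 4 (0.01 log units; within the scatter), stays within the scatter, so in this assay this added methyl leaves the number unchanged. The large change lies elsewhere: a 17-fold higher number from compound 2 to compound 4 (1.24 log units; beyond the scatter), with cyano in place of isopropylsulfonyl on an aromatic carbon and the isopropyl on the ring nitrogen the same in both. Nothing available here explains why this swap carries such a step.

Still open, as far as these compounds go, is how a primary amide or a methylsulfonyl group on that aromatic carbon would compare. From the compounds shown here alone, a longer chain or a carboxylic acid on the ring nitrogen also remains open.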